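A few compounds are considered here, and "the series" means these few. Any claim that something is new, unique, unknown or untested is made for them only; others in the source may bear on it.

Compound 1 `COc1cc2nc(OC3CCN(C(=O)OC(C)(C)C)CC3)nc(Nc3ccc(S(C)(=O)=O)cc3F)c2cc1OC`; in a functional assay on HEK293 cells for agonist activity at Glucose-dependent insulinotropic receptor (Homo sapiens), read by cAMP accumulation, with a stated time of 60 min (a higher number here means that more compound is needed for the effect, a lower number that less compound is needed), compound 1 gives > 10000 nM, which is a limit of the assay and not a number.
Compound 2 `COc1cc2nc(N3CCC4CCC(C3)N4Cc3ccccc3)nc(Nc3ccc(S(C)(=O)=O)cc3)c2cc1OC`; in this assay compound 2 gives > 10000 nM, also a limit.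
Compound 3 `COc1cc2nc(N3CCC4CCC(C3)N4Cc3ccccc3)nc(Nc3ccc(S(C)(=O)=O)cc3F)c2cc1OC`; in this assay compound 3 gives > 10000 nM, again a limit.

Compound 3 therefore stands at the limit of this assay, with no number of its own. Among the measured compounds shown here, the one step among the measured compounds, a step that the two limits leave unreadable from compound 2 to compound 3, introducing fluoro in place of hydrogen on an aromatic carbon, cannot be read in size because both ends sit at the limit, as the limit of > 10000 nM in this assay, at which 3 of the 3 values shown sit, records for every value shown.

Compound 4 `COc1cc2nc(N3CCC4CCC(C3)N4C(=O)OC(C)(C)C)nc(Nc3ccc(S(C)(=O)=O)cc3F)c2cc1OC` differs from compound 3 in one place: tert-butoxycarbonyl in place of benzyl on an amine nitrogen in a ring. For the measured compounds named here, no measured step bears on this change, since none of the three compounds has a readable value; compound 1, which carries a tert-butoxycarbonyl on a different ring, also sits at its limit > 10000 nM. With nothing to point in either direction, the step that the limit leaves unreadable from compound 3 to compound 4 is expected to be none beyond the scatter, with a limit the most likely outcome. Compound 4 is accordingly estimated at 15000 nM, within 3000 nM to 60000 nM.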

Compound 4, half-maximal effective concentration: 1000 nM
The estimate for compound 4 lay 15-fold (1.18 log units) above the measured number; the measured number lies below the stated range.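

On an amine nitrogen in a ring of a five-membered non-aromatic ring, part of a fused or bridged system of two rings, tert-butoxycarbonyl in place of benzyl gives an at least 10-fold lower number from compound 3 to compound 4 (1.00 log units; beyond the scatter) in this assay, so this position can change the read-out, which no earlier compound had shown. The two groups have the same heavy-atom count but differ in kind: benzyl has a six-membered aromatic ring of carbon only, whereas tert-butoxycarbonyl has no ring and brings oxygen, hydrogen-bond acceptors and a double bond outside aromatic rings. Compound 4 is the only compound here with a number of its own, and the other compounds remain at a limit: the limit of > 10000 nM in this assay, at which 3 of the 4 values shown sit.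

Which part of tert-butoxycarbonyl matters remains open, and a methyl carbamate, an acetyl amide or a urea on this nitrogen would help to separate the carbonyl from the tert-butyl. Among the compounds shown here, the role of the fluoro on the aromatic ring also remains open, as its one step cannot be read and there is no partner for compound 4 with hydrogen in its place.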